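Triazole in Place of Tetrazole: An Expected Step

The source may report more compounds than this note shows. Statements on the series, on what has been measured and on what is new or still open speak of the compounds shown alone.

compound 1 `CCC(C)(C)Cc1c[nH]c(CCc2ccc(N3CCCC[C@@H]3C(=O)O)cc2)n1` gives 12 nM
compound 2 `CCC(C)(C)Cc1c[nH]c(CCc2ccc(N3CCCC[C@@H]3c3nnn[nH]3)cc2)n1` gives 16 nM

Both numbers come from a functional assay for agonist activity at Bombesin receptor subtype-3 (Mus musculus); on this read-out lower numbers stand for an effect already at smaller amounts and higher numbers for an effect only at larger amounts of compound. Among the compounds with values here, compound 2 stands as the higher of the two numbers, with compound 1 as its only neighbour; the step of a 1.3-fold higher number from compound 1 to compound 2 (0.12 log units; within the scatter) lies within the scatter, so the two compounds cannot be told apart on these data.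

Compound 3 `CCC(C)(C)Cc1c[nH]c(CCc2ccc(N3CCCC[C@@H]3c3ncn[nH]3)cc2)n1` differs from compound 2 by 1H-1,2,4-triazol-5-yl in place of 1H-tetrazol-5-yl on a saturated ring carbon. Within the data shown here, no measured step matches this exchange. Among the measured compounds shown here, the one step on record, a 1.3-fold higher number from compound 1 to compound 2 (0.12 log units; within the scatter), changed the group at the same saturated ring carbon and stayed within the scatter, which shows only that this position tolerated that earlier exchange; it gives no direct guide for the present one. The expectation is therefore a small move toward a higher number, possibly still within the scatter, with wide uncertainty. Compound 3 is expected to give 40 nM, in a range from 10 nM to 160 nM, an expected step of a 2.5-fold higher number from compound 2 to compound 3 (0.40 log units; beyond the scatter).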

Compound 3, half-maximal effective concentration: 13 nM
Beside the measured number, compound 3's estimate is 3.1-fold (0.49 log units) above it, and the stated range covers the measured number.
By their numbers in this assay, from the lowest: compounds 1, 3 and 2 (each within the scatter of the next).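

In this assay, the step of a 1.2-fold lower number from compound 2 to compound 3 (0.09 log units; within the scatter) shows that on this saturated ring carbon, next to the ring nitrogen, 1H-1,2,4-triazol-5-yl and 1H-tetrazol-5-yl cannot be told apart, even though the entering ring has one carbon in place of a nitrogen and 2 hydrogen-bond acceptors rather than 3. The step of a 1.1-fold higher number from compound 1 to compound 3 (0.03 log units; within the scatter) likewise leaves the triazole indistinguishable from the carboxy group of compound 1. Within the data shown here, the position has therefore now accepted three different groups on this read-out, where the earlier pair offered only one exchange.

Nothing available bears on why these three groups read alike. As far as these compounds go, it remains open whether a group without an aromatic ring or a carboxy function, such as a primary amine or a methyl ester, would also read alike on this carbon.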